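Swapping the Sulfonyl Aryl Group Toward an Aminodibromophenyl

The source may hold more compounds than are shown below. What is called first, only, known or untested is meant among the compounds shown, and "the series" means these compounds.

In an assay on HEK293 cells for displacement of a labelled ligand from 5-hydroxytryptamine receptor 6 (Homo sapiens), with a stated time of 60 min, tested at 0.01 uM, in the presence of a further agent that is not named here (a higher number here means a stronger effect of the compound at the concentration tested, a lower number a weaker effect), compound 2 `COc1ccc(S(=O)(=O)NCCN2CCC(CCC(=O)c3cc(Cl)c(N)cc3OC)CC2)cc1Br` is reported as "not active" (no number reported), so it offers no single number to start from. Compound 4 `COc1cc(N)c(Cl)cc1C(=O)CCC1CCN(CCNS(=O)(=O)c2cc(Br)c(N)c(Br)c2)CC1` differs from it in one place: 4-amino-3,5-dibromophenyl in place of 3-bromo-4-methoxyphenyl on a sulfonyl sulfur. The other measured compounds show what an amino group on this ring can do. Compound 1 `COc1cc(N)c(Cl)cc1C(=O)CCC1CCN(CCNS(=O)(=O)c2cc(Br)ccc2Br)CC1` gives 16%, while compound 3 `COc1cc(N)c(Cl)cc1C(=O)CCC1CCN(CCNS(=O)(=O)c2ccc(N)c(Br)c2)CC1` gives 39%, and the step of a number 23 percentage points higher from compound 1 to compound 3 (beyond the scatter) was modest but beyond the scatter. Compound 4 carries the 4-amino-3,5-dibromophenyl group, which includes that same amino group, so a rise from compound 2 is expected, though its size stays uncertain since compound 2 has no number. Compound 4 is therefore estimated at 28%, within a range from 8% to 50%.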

Compound 4, a percentage reported as inhibition, at one concentration (the size of the read-out at that concentration, not a potency): 52%
Estimate against measurement, compound 4: 24 percentage points below, outside the stated range (above it).
By their numbers in this assay, from the lowest: compound 1; then compound 3; then compound 4.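

In this assay, bromo in place of hydrogen on an aromatic carbon gives a number 13 percentage points higher from compound 3 to compound 4 (beyond the scatter) and so adds to what the amino-bearing ring of compound 3 already reached. The full 4-amino-3,5-dibromophenyl group in place of 2,5-dibromophenyl on a sulfonyl sulfur gives a number 36 percentage points higher from compound 1 to compound 4 (beyond the scatter) and is a large step. No measured evidence here explains either step. The step from compound 2 to compound 4 cannot be read, as compound 2 has no number. Going by these compounds, it remains open whether chloro in place of bromo, or an acetamide in place of the amino group, would keep this read-out.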